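Cyclopentylsulfanyl in Place of (4-Fluorobenzyl)oxy

The source may hold more compounds than are shown below. What is called first, only, known or untested is meant among the compounds shown, and "the series" means these compounds.

Measured compounds:
compound 1 `CC(C)Oc1nc(C(C)(C)C)ccc1CNC(=O)C(C)c1ccc(NS(C)(=O)=O)c(F)c1` with 2.3 nM in an assay on cells for antagonist activity at transient receptor potential cation channel subfamily V member 1 (Homo sapiens), read by FLIPR and calcium flux, with a stated time of 6 min; on this read-out lower numbers stand for stronger inhibition and higher numbers for weaker inhibition
compound 2 `CC(C(=O)NCc1ccc(C(C)(C)C)nc1OCc1ccc(F)cc1)c1ccc(NS(C)(=O)=O)c(F)c1` with 0.8 nM in this assay

In this assay compound 2 gives the lowest of the two numbers shown, and its nearest neighbour is compound 1, which gives 2.3 nM. Going by the values given here, the single measured step, a 2.9-fold lower number from compound 1 to compound 2 (0.46 log units; beyond the scatter), is modest but beyond the scatter, and it concerns the same position on the ring that is now changed again.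

Compound 3 `CC(C(=O)NCc1ccc(C(C)(C)C)nc1SC1CCCC1)c1ccc(NS(C)(=O)=O)c(F)c1` differs from compound 2 in one place: cyclopentylsulfanyl in place of (4-fluorobenzyl)oxy on an aromatic carbon. Among the compounds with values here, no measured step exchanges an oxygen-linked group for a sulfur-linked one, nor an aromatic ring for a non-aromatic one at this place, so the only guidance is the step from compound 1 to compound 2, which shows that this position tolerates groups of different size with a modest shift in the numbers.

Compound 3 is therefore expected to land close to compound 2, with the step of a 1.9-fold higher number from compound 2 to compound 3 (0.27 log units; within the scatter) most likely within or only slightly beyond the scatter. The estimated value for compound 3 in this assay is 1.5 nM, in a range from 0.5 nM to 5 nM.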

Compound 3, inhibition constant: 2.5 nM
Compound 3: middle estimate off by 1.7-fold (0.22 log units), on the low side, within the range that was stated.
By their numbers in this assay, from the lowest: compound 2; then compounds 1 and 3 (each within the scatter of the next).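

In this assay, the change shows that the gain seen with (4-fluorobenzyl)oxy does not carry over to every larger group at this place on the ring: cyclopentylsulfanyl gives a 3.1-fold higher number from compound 2 to compound 3 (0.49 log units; beyond the scatter) and so loses the advantage of compound 2. The second new comparison, a 1.1-fold higher number from compound 1 to compound 3 (0.04 log units; within the scatter) for cyclopentylsulfanyl in place of isopropoxy, shows that these two groups cannot be told apart here, even though one is linked through sulfur and the other through oxygen; among the three compounds, only compound 2 stands apart from the others, and it is the most potent of them. The data shown offer no explanation for why the number moves at this position.

Compound 2 and compound 3 differ in both the linking atom and the ring, so the contributions of sulfur in place of oxygen and of a five-membered non-aromatic ring in place of a six-membered aromatic ring cannot be separated. As far as these compounds go, it remains open how a cyclopentyloxy group, a (4-fluorobenzyl)sulfanyl group or an amine such as piperidine would read at this place.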